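Benzyl Ether to Allyl Ether on a Shared Core

This account rests on a few compounds, and the source may have more. Where it says the series, first, only, none or still open, it means among the compounds named here.

Compound 2 `CN(C)CCNc1ccnc2cc(OCc3ccccc3)ccc12` is the reference point. In a functional assay on HepG2 cells (Homo sapiens) for cytotoxicity, read by MTT assay, with a stated time of 48 h (a higher number here means a weaker inhibitor, a lower number a stronger inhibitor), compound 2 gives 3120 nM, the highest of the three numbers in hand. Its nearest neighbour is compound 3 `Clc1ccnc2cc(OCc3ccccc3)ccc12`, which in this assay gives 2680 nM; the step of a 1.2-fold lower number from compound 2 to compound 3 (0.07 log units; within the scatter) leaves the two within the scatter of each other. The furthest is compound 1 `CN(C)CCNc1ccnc2cc(OCc3ccc(F)cc3)ccc12`, which gives 790 nM in this assay, and the step of a 3.9-fold higher number from compound 1 to compound 2 (0.60 log units; beyond the scatter) is a modest one, beyond the scatter.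

Compound 4 `C=CCOc1ccc2c(NCCN(C)C)ccnc2c1` differs from compound 2 in one place: vinyl in place of phenyl on a saturated chain carbon bound to an oxygen on an aromatic ring. Of the measured steps, only a 3.9-fold higher number from compound 1 to compound 2 (0.60 log units; beyond the scatter) touches the benzyloxy group, and there a single fluoro on the phenyl moved the number modestly. The step of a 1.2-fold lower number from compound 2 to compound 3 (0.07 log units; within the scatter) concerns the other end of the core and says nothing about the ether. Within the data shown here, no measured pair shows the phenyl itself being removed, so the direction of the change is open. A step of roughly the size seen between compound 1 and compound 2 is expected, in either direction, with a slight lean toward a higher number. The expected step is a 1.4-fold higher number from compound 2 to compound 4 (0.16 log units; within the scatter). Compound 4 is therefore estimated at 4500 nM, with a range from 1500 nM to 14000 nM.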

Compound 4, half-maximal inhibitory concentration: 1660 nM
Estimate against measurement, compound 4: 2.7-fold (0.43 log units) above; measured number inside the range.
By their numbers in this assay, from the lowest: compound 1; then compounds 4, 3 and 2 (each within the scatter of the next).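

In this assay, the phenyl of the benzyloxy group gives way to vinyl, six heavy atoms replaced by two, and the reading moves only within the scatter: a 1.9-fold lower number from compound 2 to compound 4 (0.27 log units; within the scatter). At this saturated chain carbon bound to the ether oxygen, the benzyloxy and allyloxy groups therefore cannot be told apart, so an aromatic ring in that place is not required for a number of this size. The 4-fluorophenyl group does separate from vinyl, with a 2.1-fold higher number from compound 1 to compound 4 (0.32 log units; beyond the scatter), a modest step beyond the scatter that, together with the earlier fluoro step, sets compound 1 apart from both compound 2 and compound 4, though nothing available explains this difference.

The compounds shown leave open whether a saturated propyl group, a longer chain such as butyl, or a chain ending in an amine would read like the allyl group at this place. They also leave open whether chloro in place of (2-(dimethylamino)ethyl)amino would make as little difference on the allyloxy compound as it does on the benzyloxy one.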